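This account rests on a few compounds, and the source may have more. Where it says the series, first, only, none or still open, it means among the compounds named here.

Values in a functional assay on SH-SY5Y cells (Homo sapiens) for cytotoxicity, read by MTT assay, with a stated time of 72 h; on this read-out higher numbers stand for weaker inhibition and lower numbers for stronger inhibition:
- Compound 1 `O=C1c2c[n+]([O-])c3ccccc3c2C(=O)c2c1c1ccccc1n2Cc1cn(C[C@H](O)CO)nn1`: > 1000 nM (a limit of the assay)
- Compound 2 `O=C1c2c[n+]([O-])c3ccccc3c2C(=O)c2c1c1ccccc1n2CCCCN1CCNCC1`: 1240 nM
- Compound 3 `O=C1c2c[n+]([O-])c3ccccc3c2C(=O)c2c1c1ccccc1n2CCCCN1CCCCC1`: 230 nM

Compound 1 has no number here, only the limit. Compound 4 `O=C1c2c[n+]([O-])c3ccccc3c2C(=O)c2c1c1ccccc1n2Cc1cn([C@@H]2O[C@H](CO)[C@@H](O)[C@H](O)[C@H]2O)nn1` carries 3,4,5-trihydroxy-6-(hydroxymethyl)oxan-2-yl in place of 2,3-dihydroxypropyl on an aromatic nitrogen.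

The nearest measured steps are a step that the limit leaves unreadable from compound 1 to compound 2 and an at least 4.3-fold lower number from compound 1 to compound 3 (0.63 log units; beyond the scatter), with a 5.4-fold lower number from compound 2 to compound 3 (0.73 log units; beyond the scatter) alongside them. All three concern the chain on the core. Compound 2 and compound 3 lack the five-membered aromatic ring, so none of these steps gives a direct size for this change.

No shift beyond the scatter is expected in this assay, and the expected step is a step that the limit leaves unreadable from compound 1 to compound 4. The expected value for compound 4 is 1500 nM, with an estimated range of 700 nM to 5000 nM.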

Compound 4, half-maximal inhibitory concentration: 880 nM
Beside the measured number, compound 4's estimate is 1.7-fold (0.23 log units) above it; low and high end bracket the measured number.
By their numbers in this assay, from the lowest: compound 3; then compounds 4 and 2 (each within the scatter of the next).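

In this assay, going by these compounds alone, compound 4 gives the first readable number for a compound with the five-membered aromatic ring, with 3,4,5-trihydroxy-6-(hydroxymethyl)oxan-2-yl in place of 2,3-dihydroxypropyl on its aromatic nitrogen. Compound 1 stands only as a limit: the limit of > 1000 nM in this assay, at which 1 of the 4 values shown sits. The change gives an at least 1.1-fold lower number from compound 1 to compound 4 (0.05 log units; that floor lies within the scatter), so this position carries the larger group without a rise in the number, while the true size of the step stays unreadable.

On these data alone, whether an amine, a carboxylic acid or a longer chain on this aromatic nitrogen would move the number remains open.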